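The source may report more compounds than this note shows. Statements on the series, on what has been measured and on what is new or still open speak of the compounds shown alone.

Compound 3 `CC(C(=O)NCc1ccc(C(F)(F)F)cc1Cl)c1ccc(NS(C)(=O)=O)c(F)c1` gives 4 nM in an assay on CHO cells for antagonist activity at transient receptor potential cation channel subfamily V member 1 (Homo sapiens), read by FLIPR (a higher number here means a weaker inhibitor, a lower number a stronger inhibitor), the highest of the three numbers recorded here. Compound 1 `CC(C(=O)NCc1ccc(C(F)(F)F)cc1OC1CCCC1)c1ccc(NS(C)(=O)=O)c(F)c1` gives 0.6 nM and compound 2 `CCCCSc1cc(C(F)(F)F)ccc1CNC(=O)C(C)c1ccc(NS(C)(=O)=O)c(F)c1` gives 1.9 nM. The measured steps show a 6.7-fold higher number from compound 1 to compound 3 (0.82 log units; beyond the scatter) and a 2.1-fold higher number from compound 2 to compound 3 (0.32 log units; beyond the scatter), so compound 3 sits at the weak end of the set, while a 3.2-fold higher number from compound 1 to compound 2 (0.50 log units; beyond the scatter) separates the two larger substituents from each other. Compound 4 `COc1ccc(-c2cc(C(F)(F)F)ccc2CNC(=O)C(C)c2ccc(NS(C)(=O)=O)c(F)c2)cc1OC` differs from compound 3 by 3,4-dimethoxyphenyl in place of chloro on an aromatic carbon. The two steps that bear on this change both show a larger group on that carbon giving a lower number than chloro, though the new group is an aromatic ring rather than the groups carried by compound 1 and compound 2, and neither step shows how such a ring behaves at this position. A modest lowering of the number is therefore expected, a 2.0-fold lower number from compound 3 to compound 4 (0.30 log units; within the scatter). Compound 4 is estimated to give 2 nM in this assay, with a range from 0.5 nM to 8 nM.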

Compound 4, inhibition constant: 8.6 nM
Beside the measured number, compound 4's estimate is 4.3-fold (0.63 log units) below it; the measured number lies above the stated range.
By their numbers in this assay, from the lowest: compound 1; then compound 2; then compound 3; then compound 4.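

With 3,4-dimethoxyphenyl on this aromatic carbon the number rises rather than falls (a 2.2-fold higher number from compound 3 to compound 4 (0.33 log units; beyond the scatter)), so in this assay a larger group here does not by itself give a lower number than chloro, which is all that compound 1 and compound 2 had shown. This aromatic ring gives a higher number than either of the other two large groups (a 4.5-fold higher number from compound 2 to compound 4 (0.66 log units; beyond the scatter); a 14-fold higher number from compound 1 to compound 4 (1.16 log units; beyond the scatter)), and the second of these steps is the only large one in the set. Nothing available accounts for the difference between this ring and cyclopentyloxy or butylsulfanyl.

The compounds shown do not separate the aromatic ring from its two methoxy groups, so an unsubstituted phenyl on this carbon remains an open case. Also open, from the compounds shown here alone, is how a pyridine ring or a smaller alkoxy group such as methoxy would compare here.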